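The source may report more compounds than this note shows. Statements on the series, on what has been measured and on what is new or still open speak of the compounds shown alone.

In an ADME assay on HepG2 2.2.15 cells (Homo sapiens) for cytotoxicity (on this read-out lower numbers stand for higher toxicity in this test and higher numbers for lower toxicity in this test), compound 1 (`O=c1[nH]c2ccc(Cl)cc2c(-c2ccccc2Cl)c1CCO`) gives 380000 nM and compound 2 (`CCCCC(=O)OCCc1c(-c2ccccc2Cl)c2cc(Cl)ccc2[nH]c1=O`) gives 200000 nM within the scatter of each other. Compound 3 (`CCCCCCCC(=O)OCCc1c(-c2ccccc2Cl)c2cc(Cl)ccc2[nH]c1=O`) differs from compound 2 by propyl in place of hydrogen on a saturated chain carbon, four bonds along the chain from a carbonyl carbon in the form of propyl in place of hydrogen on a saturated chain carbon, four bonds along the chain from a carbonyl carbon. For the measured compounds named here, the one measured step bearing on this is a 1.9-fold lower number from compound 1 to compound 2 (0.28 log units; within the scatter) and it came with butylcarbonyl in place of hydrogen on an oxygen on a saturated carbon, so no step beyond the scatter is expected in this assay here. The expected 1.3-fold lower number from compound 2 to compound 3 (0.12 log units; within the scatter) is an estimate only. Compound 3 is estimated at 150000 nM with 60000 nM to 320000 nM as the expected range.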

Compound 3, half-maximal cytotoxic concentration: 78000 nM
Compound 3: the middle estimate sits 1.9-fold (0.28 log units) above what was measured, within the range that was stated.
By their numbers in this assay, from the lowest: compound 3; then compounds 2 and 1 (each within the scatter of the next).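

In this assay, propyl in place of hydrogen on a saturated chain carbon, four bonds along the chain from a carbonyl carbon, gives a 2.6-fold lower number from compound 2 to compound 3 (0.41 log units; beyond the scatter) and so shows that this end of the ester chain can shift the read-out beyond the scatter. Heptylcarbonyl in place of hydrogen on the oxygen gives a 4.9-fold lower number from compound 1 to compound 3 (0.69 log units; beyond the scatter) while butylcarbonyl at that oxygen stayed within the scatter, so among these compounds only the longer acyl chain separates from compound 1. Nothing available explains this shift. On these data alone, whether a longer chain lowers the number further remains open. So does the effect of an amine or a carboxylic acid at the chain end.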